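The compounds below may be only part of what the source reports. "The series", "measured", "known", "first", "only" and "open" are said of these compounds alone.

The measured compounds are:

compound 1, `C=Cc1cc(=O)[nH]c(=O)n1C1O[C@H](CO)[C@@H](O)[C@H]1O`: 12000 nM
compound 2, `C/C=C/c1cc(=O)[nH]c(=O)n1C1O[C@H](CO)[C@@H](O)[C@H]1O`: > 35000 nM
compound 3, `C=Cc1cc(O)nc(O)n1`: 3000 nM

In a functional assay on L1210 cells (Mus musculus) for inhibition (a lower number here means a stronger inhibitor, a higher number a weaker inhibitor), compound 1 gives 12000 nM. The value of compound 2 in this assay is a limit, > 35000 nM, not a number. The change between them is prop-1-en-1-yl in place of vinyl on an aromatic carbon, and it brings an at least 2.9-fold higher number from compound 1 to compound 2 (0.46 log units; beyond the scatter); the size of that step is only a lower bound, resting on (the limit of > 35000 nM in this assay, at which 1 of the 3 values shown sits). Compound 3 gives 3000 nM in this assay. The difference between the core of compound 3 and the core of compound 1 is not broken down here; what the two values show is that compound 3 sits lower than compound 1.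

The unmeasured compound 4 is `C/C=C/c1cc(O)nc(O)n1`. It stands to compound 3 as compound 2 stands to compound 1: prop-1-en-1-yl in place of vinyl on an aromatic carbon. The place is described differently around the two pairs: in compound 1 it is ortho to a group of 9 heavy atoms and meta to two groups of 1 heavy atom each, whereas in compound 3 it is meta to two hydroxy groups (1 heavy atom each). It is therefore the same kind of change, not the same change. The step from compound 3 to compound 4 in this assay is expected to be a 4.0-fold higher number from compound 3 to compound 4 (0.60 log units; beyond the scatter), resting on the weakening seen in an at least 2.9-fold higher number from compound 1 to compound 2 (0.46 log units; beyond the scatter). The value of compound 4 is estimated at 12000 nM, with a range of 4000 nM to 35000 nM expected.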

Compound 4, half-maximal inhibitory concentration: > 90000 nM
Compound 4: a limit, no number (the forecaster's own chance of this, stated with the estimate: 20%); at least 7.5-fold (0.87 log units) between middle value and limit.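

In this assay, prop-1-en-1-yl in place of vinyl on an aromatic carbon gives an at least 30-fold higher number from compound 3 to compound 4 (1.47 log units; beyond the scatter), so the weakening seen on the core of compound 1 appears again on the core of compound 3, and the change runs the same way in both pairs: the same change on two cores in this assay, an at least 2.9-fold higher number (0.46 log units; beyond the scatter) from compound 1 to compound 2 and an at least 30-fold higher number (1.47 log units; beyond the scatter) from compound 3 to compound 4; the limit leaves it open whether they differ. Compound 4 stands at a limit, not a number: the limit of > 90000 nM in this assay, at which 1 of the 4 values shown sits. Compound 2 also stands at a limit, not a number, so both steps are lower bounds, and the two pairs show the direction of the change on these two cores but not whether it weakens one core more than the other: the limit of > 35000 nM in this assay, at which 1 of the 4 values shown sits.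

The compounds shown leave open what a longer chain than prop-1-en-1-yl, or an ethyl group in place of vinyl, would do on either core. They also leave open how an amine or a carboxylic acid at this place would read in this assay, and how large the weakening on each core would prove to be if numbers stood in place of the limits.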